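Methoxy entry at the aryl of compound 3

The source may report more compounds than this note shows. Statements on the series, on what has been measured and on what is new or still open speak of the compounds shown alone.

Three members of the series carry a measurement in a functional assay on the whole organism (strain Albino) for inhibition, with Rattus norvegicus as the target, with stated times of 1 h and 3 h, at a dose of 20 mg/kg by the oral route; on this read-out lower numbers stand for less inhibition and higher numbers for more inhibition at the one dose given (going by the name of the read-out). Compound 1 `O=C(O)CCC1=C(c2ccc(Cl)cc2)NC(=S)NC1c1ccccc1O` gives 1.22%, compound 2 `COc1cc(C2NC(=S)NC(c3ccc(C)cc3)=C2CCC(=O)O)cc(OC)c1OC` gives 16%, and compound 3 `O=C(O)CCC1=C(c2ccccc2)NC(=S)NC1c1ccccc1O` gives 12.9%. Among these three numbers compound 3 stands second highest; its nearest neighbour is compound 2, which lies within the scatter of it, while compound 1 lies beyond the scatter below it. For the measured compounds named here, the only single-point step available is a number 11.7 percentage points higher from compound 1 to compound 3 (beyond the scatter), which concerns the exchange of chloro for hydrogen on an aromatic carbon and has no bearing on a methoxy entering.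

Compound 4 `COc1ccc(C2=C(CCC(=O)O)C(c3ccccc3O)NC(=S)N2)cc1` differs from compound 3 by methoxy in place of hydrogen on an aromatic carbon. Going by the values given here, no measured pair isolates this change, so nothing shows what a methoxy on an aromatic carbon para to a large group does to this assay. Compound 2, with methoxy groups on its other aryl ring, sits within the scatter of compound 3, which gives no reason to expect a shift. The step from compound 3 to compound 4 is therefore expected to lie within the scatter, as a number 1.1 percentage points higher from compound 3 to compound 4 (within the scatter). For compound 4 the expected value in this assay is 14%, with a range from 4% to 26%.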

Compound 4, a percentage reported as inhibition, in the whole organism at one dose (the size of the read-out at that dose, not a potency): 20.9%
Compound 4: the middle estimate sits 6.9 percentage points below what was measured; the measured number falls inside the stated range.
By their numbers in this assay, from the lowest: compound 1; then compounds 3, 2 and 4 (each within the scatter of the next).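

Notes on the aryl position para to a large group: in this assay, phenyl to 4-methoxyphenyl gives a number 8 percentage points higher from compound 3 to compound 4 (within the scatter), so the methoxy and hydrogen compounds cannot be told apart at this position. For the compounds shown here, the methoxy compound does separate from the chloro compound, with a number 19.7 percentage points higher from compound 1 to compound 4 (beyond the scatter), and together with a number 11.7 percentage points higher from compound 1 to compound 3 (beyond the scatter) this leaves chloro as the only one of the three groups at this position that stands apart from the others, while hydrogen and methoxy stay together. Nothing at hand bears on the reason for this separation.

As far as these compounds go, it remains open whether an amine such as dimethylamino, or a longer chain such as ethoxy, at the same position would stay with hydrogen and methoxy or fall with chloro in this assay. From the compounds shown here alone, these steps also rest on single compounds sharing the rest of their structure and on a read-out at one dose, so it is open whether they hold with the other aryl substitution seen in compound 2, or at other doses.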